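Acetyl versus dimethylamino on the pendant phenyl ring

This account rests on a few compounds, and the source may have more. Where it says the series, first, only, none or still open, it means among the compounds named here.

Measured so far:
compound 1 `COc1cc(C)cc(-c2c(-c3ccnc(-c4ccc(C(C)=O)cc4)c3)cnn2CC#N)c1`: > 100000 nM
compound 2 `Cc1cc(O)cc(-c2nn(CC#N)cc2-c2ccnc(-c3ccc(N(C)C)cc3)c2)c1`: 17500 nM

Both values come from a functional assay on SW-620 cells (Homo sapiens) for inhibition, read by sulforhodamine B assay, with a stated time of 48 h; a lower number here means a stronger inhibitor of growth, a higher number a weaker inhibitor of growth. For compound 1 the result is not a number but a limit of the assay, > 100000 nM. Compound 1 therefore stands at the limit of > 100000 nM in this assay, at which 1 of the 2 values shown sits. Compound 2, in this assay , gives a number, 17500 nM. Among the compounds with values here, no step between two measured compounds that differ in a single place is available, so the comparison of compound 1 with compound 2 shows only a limit on one side and a number on the other.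

Compound 3 `COc1cc(C)cc(-c2c(-c3ccnc(-c4ccc(N(C)C)cc4)c3)cnn2CC#N)c1` is yet to be measured in this assay . Its difference from compound 1 is dimethylamino in place of acetyl on an aromatic carbon. Compound 2 carries the dimethylamino group and gives a number, 17500 nM. The step expected from compound 1 to compound 3 is therefore one into the measurable range, toward stronger growth inhibition, as an at least 3.3-fold lower number from compound 1 to compound 3 (0.52 log units; beyond the scatter). For compound 3 the estimate is 30000 nM, expected between 8000 nM and 100000 nM.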

Compound 3, concentration for total growth inhibition: > 100000 nM
Compound 3: only a limit was reported; the forecaster's own chance of this, stated with the estimate: 30%; middle value at least 3.3-fold (0.52 log units) away from the limit.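

In this assay compound 1 gives > 100000 nM, a limit of the assay. Compound 3 gives > 100000 nM, also a limit, so no step can be read between compound 1 and compound 3 because both sit at the same limit: the limit of > 100000 nM in this assay, at which 2 of the 3 values shown sit.

The compounds shown leave open whether dimethylamino in place of acetyl on an aromatic carbon changes growth inhibition on this core at all.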